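From pyridin-2-yl to 1H-indol-6-yl on the amino nitrogen

The source may report more compounds than this note shows. Statements on the series, on what has been measured and on what is new or still open speak of the compounds shown alone.

For the measured compounds named here, in a functional assay on K562 cells (Homo sapiens) for inhibition, read by trypan blue exclusion, with a stated time of 72 h (on this read-out lower numbers stand for stronger inhibition and higher numbers for weaker inhibition), compound 2 (`Cn1c(=O)c(S(=O)(=O)c2ccc(F)cc2F)cc2cnc(Nc3ccccn3)nc21`) gives 35000 nM, the higher of the two numbers measured so far and so the weaker inhibition. Compound 3 (`Cn1c(=O)c(S(=O)(=O)c2ccc(F)cc2F)cc2cnc(Nc3ccc4cc[nH]c4c3)nc21`) has not yet been measured. It departs from compound 2 by a single change, 1H-indol-6-yl in place of pyridin-2-yl on a nitrogen on an aromatic ring. Going by the values given here, no measured pair isolates this change, so its size cannot be read directly. Among the compounds with values here, the only guide is compound 1 (`Cn1c(=O)c(S(=O)(=O)c2ccc(F)cc2)cc2cnc(Nc3ccc4cc[nH]c4c3)nc21`), which also carries 1H-indol-6-yl and gives 10000 nM, a number lower than that of compound 2 by more than the usual scatter. A moderate fall toward stronger inhibition is therefore expected, with an estimated step of a 3.5-fold lower number from compound 2 to compound 3 (0.54 log units; beyond the scatter). For compound 3 the expected value is 10000 nM, with an estimated range of 3500 nM to 28000 nM.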

Compound 3, half-maximal inhibitory concentration: 5000 nM
Compound 3: middle estimate off by 2.0-fold (0.30 log units), on the high side; the range from low to high includes it.
By their numbers in this assay, from the lowest: compounds 3 and 1 (each within the scatter of the next); then compound 2.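

In this assay the change on the amino nitrogen can now be read directly: with the rest of the molecule held fixed, 1H-indol-6-yl in place of pyridin-2-yl gives a 7.0-fold lower number from compound 2 to compound 3 (0.85 log units; beyond the scatter) and so shows that this position responds to the group it carries. The other change, fluoro in place of hydrogen on an aromatic carbon, gives a 2.0-fold lower number from compound 1 to compound 3 (0.30 log units; within the scatter) and does not separate the two compounds on this read-out. No measurement at hand gives a reason for either step. The compounds shown leave open whether a plain phenyl on the amino nitrogen would match 1H-indol-6-yl, which would test whether the second ring is needed. Also open, from the compounds shown here alone, is whether a chloro or a methoxy in place of that fluoro would give a step beyond the scatter.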